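From compound 3 to compound 4: one more methoxy

The compounds below may be only part of what the source reports. "The series", "measured", "known", "first", "only" and "open" are said of these compounds alone.

Measured in a functional assay (plasma) for inhibition, with Oryctolagus cuniculus as the target (on this read-out higher numbers stand for an effect only at larger amounts of compound and lower numbers for an effect already at smaller amounts), each entry a limit and not a number:
- compound 1 `COc1cc2cnn(-c3ccccc3)c(=O)c2cc1OC`: >= 100 uM
- compound 2 `COc1cc2cnn(-c3ccccc3Cl)c(=O)c2cc1OC`: >= 100 uM
- compound 3 `COc1ccc(-n2ncc3cc(OC)c(OC)cc3c2=O)cc1`: >= 100 uM

Compound 3 stands at >= 100 uM, which is a limit. It has no readable number, and the series as a whole shows (the limit of >= 100 uM in this assay, at which 3 of the 3 values shown sit).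

The step to compound 4 `COc1ccc(-n2ncc3cc(OC)c(OC)cc3c2=O)cc1OC` puts methoxy in place of hydrogen on an aromatic carbon, ortho to a methoxy group and meta to a large group (methoxy in place of hydrogen on an aromatic carbon).

Among the compounds with values here, the closest precedent is the same exchange, which gives a step that the two limits leave unreadable from compound 1 to compound 3. The chloro exchange gives a step that the two limits leave unreadable from compound 1 to compound 2. Neither step has a size that can be carried over, so the series offers no measured support for a shift in either direction in this assay. No step beyond the scatter is therefore expected, and another limit is the likeliest report.

The expected change is a number no higher from compound 3 to compound 4 (the limit leaves the size open), an estimate with no direction beyond the scatter. For compound 4 the estimated value is 100 uM, with an expected range from 40 uM to 250 uM.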

Compound 4, concentration for half-maximal effect: >= 100 uM
Compound 4 ended at the assay's limit; the forecaster's own chance of this, stated with the estimate: 75%; the middle value sits exactly at the limit.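

Within the data shown here, compound 3 and compound 4 both end at a limit, not a number, in this assay, so no step between them can be read. The whole series sits at one reported limit: the limit of >= 100 uM in this assay, at which 4 of the 4 values shown sit.

The compounds shown leave open the size and direction of the methoxy and chloro exchanges in this assay, and which change to the shared core would give a readable number.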